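Compound 2 gives up its carboxymethyl group

The source may report more compounds than this note shows. Statements on the series, on what has been measured and on what is new or still open speak of the compounds shown alone.

Two compounds have so far been followed in an ADME assay on a cell-free system (plasma, Homo sapiens) for metabolic stability, read by LC-MS; on this read-out lower numbers stand for a shorter-lived compound and higher numbers for a longer-lived compound. Compound 1, `CCCCOC(=O)c1cccc(NC(=O)c2cccc(-c3cc(C(=O)Nc4ccncc4F)ccc3CN)c2)c1`, gives < 0.0834 h, which is a limit of the assay and not a number. Compound 2, `NCc1ccc(C(=O)Nc2ccncc2F)cc1-c1cccc(C(=O)Nc2ccc(CC(=O)O)cc2)c1`, gives > 2 h, and this too is a limit. Compound 2 therefore stands at the longer-lived end of the two results, with no exact half-life known. Compound 3, `NCc1ccc(C(=O)Nc2ccncc2F)cc1-c1cccc(C(=O)Nc2ccccc2)c1`, has not yet been measured in this assay. It differs from compound 2 by hydrogen in place of carboxymethyl on an aromatic carbon, with hydrogen in place of carboxymethyl on an aromatic carbon, para to a large group. For the measured compounds named here, no measured pair shows the size of this change, so the expectation is a tentative one. No shift beyond the scatter is expected in this assay, and the estimated change is a step that the limit leaves unreadable from compound 2 to compound 3. The half-life expected for compound 3 is 2.5 h, with an estimated range of 1.2 h to 5 h.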

Compound 3, half-life: > 2 h
Compound 3: only a limit was reported (the forecaster's own chance of this, stated with the estimate: 80%); the middle value lies beyond the limit too.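

In this assay compound 3 gives > 2 h, a limit of the assay and not a number, so the carboxymethyl group, para to a large group, is not required for a half-life that reaches this limit. The change at this position between compound 2 and compound 3 cannot be read, however: the limit of > 2 h in this assay, at which 2 of the 3 values shown sit. Hydrogen in place of butoxycarbonyl on an aromatic carbon gives an at least 23-fold higher number from compound 1 to compound 3 (1.37 log units; beyond the scatter), which ties the short half-life of compound 1 to its butoxycarbonyl group and not to the shared core.

As far as these compounds go, how far compound 2 and compound 3 lie past the limit remains unknown, so carboxymethyl and hydrogen cannot be ranked. From the compounds shown here alone, it also remains open whether a smaller ester such as methoxycarbonyl, or a carboxylic acid in place of butoxycarbonyl, would keep the longer half-life.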